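Swapping a Chloropropyl Tail for a Vinyl Group

The source may hold more compounds than are shown below. What is called first, only, known or untested is meant among the compounds shown, and "the series" means these compounds.

Compound 1 `CC(C)(C)c1ccc(NC(=O)CCCCl)cc1` and compound 3 `C=CC(=O)Nc1ccc(C(C)(C)C)cc1` share one core, while compound 2 `CC(C)(C)c1ccc(CNC(=O)CCCCl)cc1` and compound 4 `C=CC(=O)NCc1ccc(C(C)(C)C)cc1` share another; the difference between the two cores is not broken down here. In a functional assay on M21 cells (Homo sapiens) for antiproliferative activity, with a stated time of 48 h (a lower number here means a stronger inhibitor, a higher number a weaker inhibitor), compound 1 gives > 100000 nM, which is a limit of the assay rather than a number. Compound 3 gives 22000 nM in this assay. The change from compound 1 to compound 3 is vinyl in place of 3-chloropropyl on a carbonyl carbon and it brought an at least 4.5-fold lower number from compound 1 to compound 3 (0.65 log units; beyond the scatter); the step can be given only as a minimum because the limit of > 100000 nM in this assay, at which 1 of the 3 values shown sits, caps what compound 1 shows. Compound 2 gives 69000 nM in this assay, a higher number than that of compound 3.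

Compound 4 arises from compound 2 by vinyl in place of 3-chloropropyl on a carbonyl carbon, the same change made at the same place. Among the compounds with values here, compound 4 is therefore expected to show a 5.8-fold lower number from compound 2 to compound 4 (0.76 log units; beyond the scatter), resting on an at least 4.5-fold lower number from compound 1 to compound 3 (0.65 log units; beyond the scatter) as the only measured example of this change. Compound 4 is accordingly estimated at about 12000 nM, most likely between 3000 nM and 40000 nM.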

Compound 4, half-maximal inhibitory concentration: 72000 nM
Estimate against measurement, compound 4: 6.0-fold (0.78 log units) below, and the stated range ends below it.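

In this assay, putting vinyl in place of 3-chloropropyl on a carbonyl carbon gave a 1.0-fold higher number from compound 2 to compound 4 (0.02 log units; within the scatter), so on this core the two compounds cannot be told apart. The change therefore did not carry over from one core to the other with the same size, and the two steps differ by more than ordinary scatter allows: the same change on two cores in this assay, an at least 4.5-fold lower number (0.65 log units; beyond the scatter) from compound 1 to compound 3 and a 1.0-fold higher number (0.02 log units; within the scatter) from compound 2 to compound 4, at least 4.7-fold (0.67 log units) apart, beyond the scatter of two such steps. This shows that a result from one core could not be transferred to the other in this pair, but two examples do not show which feature of the cores is responsible, and the earlier step can be read only as a minimum: the limit of > 100000 nM in this assay, at which 1 of the 4 values shown sits.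

Still open, as far as these compounds go, is what an ethyl group or a plain propyl chain on the carbonyl carbon would give on either core, which would separate the part played by the double bond from that of the chlorine. From the compounds shown here alone, how the same swap would behave on a third core also remains open.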